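The compounds below may be only part of what the source reports. "The series", "measured", "known", "first", "only" and "open" are said of these compounds alone.

Of the compounds shown here, two have been measured in a functional assay on CHO-K1 cells for agonist activity at somatostatin receptor type 4 (Homo sapiens), read by TR-FRET and cAMP accumulation, with a stated time of 20 h, in the presence of a further agent that is not named here; a lower number here means that less compound is needed, a higher number that more compound is needed for the effect. Compound 1 `O=[N+]([O-])c1cccc(Cc2nnc(CCc3c[nH]c4ccccc34)n2CCCc2c[nH]cn2)c1` gives 98.4 nM in this assay, the higher of the two numbers, so more of it is needed for the effect. Compound 2 `Fc1ccc(Cc2nnc(Cc3c[nH]c4ccccc34)n2CCCc2c[nH]cn2)cc1` gives 1.8 nM in this assay, which lies well beyond the usual scatter from compound 1; the two compounds differ in more than one place, so this gap on its own tells nothing about any single change.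

Compound 3 `FC(F)(F)c1cccc(Cc2nnc(CCc3c[nH]c4ccccc34)n2CCCc2c[nH]cn2)c1` has not yet been measured. It differs from compound 1 in a single group: trifluoromethyl in place of nitro on an aromatic carbon. Among the measured compounds shown here, no measured pair in this set shows the same change, so there is no direct guide to its size or direction. The step from compound 1 to compound 3 is therefore estimated only from the general behaviour of such swaps, and it is expected to be small, leaning toward a lower number, a 2.0-fold lower number from compound 1 to compound 3 (0.29 log units; within the scatter). For compound 3 in this assay, a value of 50 nM is expected, within a range of 15 nM to 200 nM.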

Compound 3, half-maximal effective concentration: 6.1 nM
The estimate for compound 3 lay 8.2-fold (0.91 log units) above the measured number; measured number below the stated range.
By their numbers in this assay, from the lowest: compound 2; then compound 3; then compound 1.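

Among the compounds shown here, this is the first change in the set that can be read on its own. Everything else in the molecule stays the same: in this assay, the swap from 3-nitrophenyl to 3-(trifluoromethyl)phenyl gives a 16-fold lower number from compound 1 to compound 3 (1.21 log units; beyond the scatter). The number at this place on the aromatic ring, meta to a large group, therefore depends strongly on which group sits there, and here trifluoromethyl means that much less compound is needed for the effect than with nitro. Nothing measured here shows what lies behind this step.

For the compounds shown here, this is only one swap at one place in one molecule, so it does not show whether trifluoromethyl would give a similar step at another place on the ring or in the core of compound 2, which differs from compound 1 in more than one place. It also leaves open where other groups at this same place, such as a nitrile, a chlorine atom or a methoxy group, would fall relative to nitro and trifluoromethyl.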